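The compounds below may be only part of what the source reports. "The series", "measured", "known", "first", "only" and "open" are said of these compounds alone.

Measured so far:
Compound 1, `CC(C)C/N=C(\NC#N)Nc1cccnc1`: 20 mg/kg
Compound 2, `CCCCC(CC)C/N=C(\NC#N)Nc1cccnc1`: > 50 mg/kg (a limit)
Compound 3, `CC(C)/N=C(\NC#N)Nc1cccnc1`: 2.5 mg/kg

All three share one core and differ only in the group carried on a double-bonded nitrogen. In a functional assay on the whole organism (blood, strain Wistar-Okamoto) with Rattus norvegicus as the target, with a stated time of 5 days (a higher number here means that more compound is needed for the effect, a lower number that less compound is needed), compound 1 gives 20 mg/kg, the higher of the two numbers reported, so more of it is needed than of compound 3. Its nearest neighbour is compound 3, and the change an 8.0-fold lower number from compound 1 to compound 3 (0.90 log units; beyond the scatter) shows that trimming the group lowers the dose needed. Compound 2 carries a longer branched chain and reaches only a limit, > 50 mg/kg. That is the limit of > 50 mg/kg in this assay, at which 1 of the 3 values shown sits.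

Compound 4, `N#CN/C(=N\c1ccccc1)Nc1cccnc1`, has not been measured. Compared with compound 1 the change is phenyl in place of isobutyl on a double-bonded nitrogen. Going by the values given here, neither measured step tests a ring on this nitrogen: the one numbered step moves toward a smaller group and lowers the dose, while the bulkier chain of compound 2 gives only a limit. Phenyl is larger than isobutyl but flat, so the two pieces of evidence pull in opposite directions. On balance no step beyond the scatter is expected, so compound 4 is estimated at 20 mg/kg, between 5 mg/kg and 50 mg/kg, which means an expected step of no change at the digits printed from compound 1 to compound 4 (within the scatter).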

Compound 4, minimum effective dose: 5 mg/kg
Compound 4: the middle estimate sits 4.0-fold (0.60 log units) above what was measured; low and high end bracket the measured number.
By their numbers in this assay, from the lowest: compounds 3 and 4 (each within the scatter of the next); then compound 1. At a limit, above all of these: compound 2.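

Until now, the groups shown on this double-bonded nitrogen were all open chains, and the only numbered step came from trimming isobutyl to isopropyl. Compound 4 shows that a group with more heavy atoms can also lower the dose needed: in this assay there is a 4.0-fold lower number from compound 1 to compound 4 (0.60 log units; beyond the scatter), so at this position the count of heavy atoms alone does not set the dose, and a six-membered aromatic ring of carbon is well tolerated. Against the small isopropyl chain, the phenyl ring gives a 2.0-fold higher number from compound 3 to compound 4 (0.30 log units; within the scatter), so compound 3 and compound 4 stand level and neither can be put ahead of the other. Compound 2, with its long branched chain, remains a limit and not a number: the limit of > 50 mg/kg in this assay, at which 1 of the 4 values shown sits.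

From the compounds shown here alone, it remains open whether a cyclohexyl ring, which has no aromatic character, would do as well as phenyl, and whether a phenyl carrying chlorine or a methoxy group would keep the dose this low. Shorter chains such as ethyl or methyl would show whether the benefit of trimming continues beyond isopropyl.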